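Nitro to Trifluoromethyl on a Weak Starting Point

The compounds below may be only part of what the source reports. "The series", "measured", "known", "first", "only" and "open" are said of these compounds alone.

Three compounds have results in a functional assay on A549 cells (Homo sapiens) for antiproliferative activity, read by MTT assay, with a stated time of 12 h; a higher number here means a weaker inhibitor, a lower number a stronger inhibitor. Compound 1 `COc1cc(OC)c2c(=O)cc(/C=C/c3ccc([N+](=O)[O-])cc3)oc2c1` gives 19700 nM in this assay, and this is the only result that is a number rather than a limit. Compound 2 `COc1ccc2oc(/C=C/c3ccc(OC(F)(F)F)cc3)cc(=O)c2c1` stops at the limit > 40000 nM. Compound 3 `COc1cccc2oc(/C=C/c3ccc(OC(F)(F)F)cc3)cc(=O)c12` also stops at the limit > 40000 nM. Two of the three results therefore sit at the limit of > 40000 nM in this assay, at which 2 of the 3 values shown sit, so every member of this group is at best weakly active. Compound 4 `COc1cc(OC)c2c(=O)cc(/C=C/c3ccc(C(F)(F)F)cc3)oc2c1` differs from compound 1 by trifluoromethyl in place of nitro on an aromatic carbon. Among the measured compounds shown here, no measured pair shows this particular change. The step from compound 1 to compound 4 is expected to be small, a 1.5-fold higher number from compound 1 to compound 4 (0.18 log units; within the scatter), a slight loss that may not exceed the scatter. Compound 4 is accordingly expected to give about 30000 nM, within 10000 nM to 90000 nM.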

Compound 4, half-maximal inhibitory concentration: > 40000 nM
Compound 4: only a limit was reported (the forecaster's own chance of this, stated with the estimate: 40%); middle value at least 1.3-fold (0.12 log units) from the limit.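

Among the compounds shown here, this is the first measured pair for this change on this aromatic carbon: trifluoromethyl in place of nitro gives an at least 2.0-fold higher number from compound 1 to compound 4 (0.30 log units; that floor lies within the scatter). As far as these compounds go, since the result for compound 4 is a limit, the true size of the step is unknown, and a real loss cannot be separated from the scatter. Compound 1 remains the only compound with a number, and the rest share one ceiling: the limit of > 40000 nM in this assay, at which 3 of the 4 values shown sit.

Whether an amine or a carboxylic acid at this position would give a number is open. So is how far beyond the limit compound 4 lies.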